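Benzyl to hydrogen on oxygen: growth inhibition notes

The source may hold more compounds than are shown below. What is called first, only, known or untested is meant among the compounds shown, and "the series" means these compounds.

Measured so far:
compound 1 `CC(C)n1nc(/C=N/OCc2ccccc2)c2c(N)ncnc21` — 9850 nM
compound 2 `Nc1ncnc2c1c(-c1cc(C3CC3)on1)nn2C1CCOCC1` — 32900 nM

Two compounds have been run in an ADME assay on Nthy-ori 3-1 cells (Homo sapiens) for cytotoxicity, read by MTT assay, with a stated time of 10 days; a higher number here means a weaker inhibitor of growth, a lower number a stronger inhibitor of growth. Compound 1 gives 9850 nM and compound 2 gives 32900 nM; compound 1 therefore stands at the lower of the two numbers, with compound 2 beyond the scatter above it. The two structures differ in more than one place, so the gap between them is only what the two values show, and no single change is assigned to it.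

Compound 3 `CC(C)n1nc(/C=N/O)c2c(N)ncnc21` is not yet measured. It differs from compound 1 in one place: hydrogen in place of benzyl on an oxygen. Within the data shown here, no step between two measured compounds changes this same place, so the size of the move has to be judged without a direct precedent.

The step expected from compound 1 to compound 3 in this assay is a 2.5-fold higher number from compound 1 to compound 3 (0.40 log units; beyond the scatter), a move toward a higher number, a size that is expected to exceed the scatter though not by a wide margin. Compound 3 is accordingly estimated at 25000 nM, with a range of 8000 nM to 80000 nM.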

Compound 3, concentration for 50% growth inhibition: 107000 nM
The estimate for compound 3 lay 4.3-fold (0.63 log units) below the measured number; measured number above the stated range.
By their numbers in this assay, from the lowest: compound 1; then compound 2; then compound 3.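

In this assay the oxygen whose other neighbour is the double-bonded nitrogen proves to be a place where the substituent matters: hydrogen in place of benzyl gives an 11-fold higher number from compound 1 to compound 3 (1.04 log units; beyond the scatter) and so marks a large loss of growth inhibition on this core. Among these compounds, with only this single pair, the step belongs to the whole exchange, and the part played by the six-membered aromatic ring cannot be separated from that of the rest of the benzyl group or from the hydrogen that enters. Nothing among the available data bears on why the number rises at this place.

Still open, on these data alone, is whether the number follows the aromatic ring or simply the presence of any carbon group on this oxygen, which a methyl group, a longer alkyl chain or a cyclohexylmethyl group there would help to separate. A substituted benzyl or a phenethyl group on the same oxygen would show whether the number can fall further than it does with benzyl itself.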